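Cytotoxicity series: piperidine carboxanilide core, varied benzyl and amine groups

The compounds below may be only part of what the source reports. "The series", "measured", "known", "first", "only" and "open" are said of these compounds alone.

Compound 1 `COc1ccc(CN2CCC(C(=O)Nc3ccc(CNc4nc(N(C)C)nc5cc(C)ccc45)cc3)CC2)cc1` — in a functional assay on SV5A8 cells (Homo sapiens) for cytotoxicity (on this read-out lower numbers stand for stronger inhibition and higher numbers for weaker inhibition), compound 1 gives > 6180 nM, a limit of the assay.
Compound 2 `CCNc1nc(NCc2ccc(NC(=O)C3CCN(Cc4ccccc4)CC3)cc2)c2ccc(C)cc2n1` — compound 2 gives > 2140 nM, a limit.
Compound 3 `Cc1ccc2c(NCc3ccc(NC(=O)C4CCN(Cc5ccccc5)CC4)cc3)nc(N3CCCCCC3)nc2c1` — compound 3 gives > 6880 nM, a limit.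

Compound 1 stands at one of three limits in this assay (the limit of > 6180 nM in this assay, at which 1 of the 3 values shown sits); the others are the limit of > 2140 nM in this assay, at which 1 of the 3 values shown sits, and (the limit of > 6880 nM in this assay, at which 1 of the 3 values shown sits), so no number separates it from compound 2 or compound 3. Among the compounds with values here, the one single-point step, a step that the two limits leave unreadable from compound 2 to compound 3, lies on an aromatic carbon and is unreadable between two limits, so nothing bears directly on the change to compound 4 `Cc1ccc2c(NCc3ccc(NC(=O)C4CCN(Cc5ccco5)CC4)cc3)nc(N(C)C)nc2c1`, namely (furan-2-yl in place of 4-methoxyphenyl on a saturated chain carbon bound to an amine nitrogen in a ring). With no readable step anywhere in the series, no change beyond the scatter is expected from compound 1 to compound 4, a step that the limit leaves unreadable from compound 1 to compound 4. Compound 4 is expected to give 7000 nM, within 3000 nM to 20000 nM, most likely again as a limit.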

Compound 4, half-maximal inhibitory concentration: > 20000 nM
Compound 4 was reported as a limit; the forecaster's own chance of this, stated with the estimate: 80%; middle value at least 2.8-fold (0.45 log units) from the limit.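

Compound 1 and compound 4 are both limits, so the step from 4-methoxyphenyl to furan-2-yl cannot be read. The compounds shown leave open what actual number any of them would give, and whether that exchange changes it.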